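Amide variation on the shared sulfonylpiperidine core

The source may report more compounds than this note shows. Statements on the series, on what has been measured and on what is new or still open speak of the compounds shown alone.

Measured so far in a functional assay on BXPC-3 cells (Homo sapiens) for inhibition, read by MTT assay, with a stated time of 7 days; on this read-out higher numbers stand for weaker inhibition and lower numbers for stronger inhibition:
- compound 1, `CCN(CC)S(=O)(=O)c1ccc(S(=O)(=O)N2CCC[C@@H](C(=O)N3CCS(=O)(=O)CC3)C2)cc1`: 4430 nM
- compound 2, `CCN(CC)S(=O)(=O)c1ccc(S(=O)(=O)N2CCC[C@@H](C(=O)N[C@H]3CC[C@H](OC)CC3)C2)cc1`: 2000 nM
- compound 3, `CCN(CC)S(=O)(=O)c1ccc(S(=O)(=O)N2CCC[C@@H](C(=O)N3CCOCC3)C2)cc1`: 790 nM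

Compound 3 holds the lowest number of the three, and both of its gaps lie beyond the scatter: a 5.6-fold lower number from compound 1 to compound 3 (0.75 log units; beyond the scatter) and a 2.5-fold lower number from compound 2 to compound 3 (0.40 log units; beyond the scatter). The third measured step, a 2.2-fold lower number from compound 1 to compound 2 (0.35 log units; beyond the scatter), is also modest. All three steps concern only the group on the carbonyl carbon; the core is unchanged.

Compound 4, `CCN(CC)S(=O)(=O)c1ccc(S(=O)(=O)N2CCC[C@@H](C(=O)N3CC[C@@H](OC)C3)C2)cc1`, is not yet measured. It differs from compound 3 in one place: 3-methoxypyrrolidin-1-yl in place of morpholin-4-yl on a carbonyl carbon. Within the data shown here, no measured step swaps one ring amide for another ring amide of different ring size, so the direction of this step is not fixed by the data. The three steps seen show that exchanges at this carbonyl move the number by modest amounts only, which sets the expected size of a 1.5-fold higher number from compound 3 to compound 4 (0.18 log units; within the scatter). Compound 2, carrying a methoxy substituent on its amide group, sits at 2000 nM, which argues against a large gain. For compound 4 the estimate in this assay is 1200 nM, with a range of 500 nM to 3000 nM.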

Compound 4, half-maximal inhibitory concentration: 11500 nM
For compound 4 the middle estimate is 9.6-fold (0.98 log units) below the measured one, outside the stated range (above it).
By their numbers in this assay, from the lowest: compound 3; then compound 2; then compound 1; then compound 4.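

In this assay, among these compounds, the group on the carbonyl carbon proves able to move the number much further than the earlier exchanges indicated: a 15-fold higher number from compound 3 to compound 4 (1.16 log units; beyond the scatter) is the only large step. With a 5.8-fold higher number from compound 2 to compound 4 (0.76 log units; beyond the scatter) and a 2.6-fold higher number from compound 1 to compound 4 (0.41 log units; beyond the scatter) as well, compound 4 now holds the highest number, above the 1,1-dioxothiomorpholin-4-yl amide, although morpholin-4-yl and 3-methoxypyrrolidin-1-yl have the same counts of hydrogen-bond donors and acceptors and neither carries a net charge. No evidence on the origin of this step is available.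

Still open, on these data alone, is whether the step follows the five-membered ring, the methoxy group or the defined stereocentre. A plain pyrrolidin-1-yl amide or a 3-hydroxypyrrolidin-1-yl amide on the shared core would help separate these.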